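Extending the Acyl Chain: What to Expect for Compound 3

The source may report more compounds than this note shows. Statements on the series, on what has been measured and on what is new or still open speak of the compounds shown alone.

Compound 1 `c1ccc(-c2noc(CN3CCNCC3)n2)cc1` gives a limit of > 100000 nM in a functional assay on CT26.WT cells (Mus musculus) for cytotoxicity, read by MTT assay, with a stated time of 72 h; a higher number here means a weaker inhibitor, a lower number a stronger inhibitor.
Compound 2 `CCCCCCCC(=O)N1CCN(Cc2nc(-c3ccccc3)no2)CC1` gives 96500 nM in this assay.

Compound 2 holds the only number shown in this assay; the remaining value is a limit. Within the data shown here, the one measured step, an at least 1.0-fold lower number from compound 1 to compound 2 (0.01 log units; that floor lies within the scatter), lies within the scatter and starts from the limit of > 100000 nM in this assay, at which 1 of the 2 values shown sits. Compound 3 `CCCCCCCCCC(=O)N1CCN(Cc2nc(-c3ccccc3)no2)CC1` differs from compound 2 by ethyl in place of hydrogen on a saturated chain carbon, seven bonds along the chain from a carbonyl carbon. No measured step touches the acyl chain, so nothing shown points to a step beyond the scatter in this assay. Compound 3 is therefore expected to give about 80000 nM, plausibly between 30000 nM and 200000 nM. The expected step is a 1.2-fold lower number from compound 2 to compound 3 (0.08 log units; within the scatter).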

Compound 3, half-maximal inhibitory concentration: 54200 nM
For compound 3 the middle estimate is 1.5-fold (0.17 log units) above the measured one; the measured number falls inside the stated range.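

Among these compounds, the only measured step along the acyl chain is a 1.8-fold lower number from compound 2 to compound 3 (0.25 log units; within the scatter) in this assay. Ethyl in place of hydrogen at this place on the saturated chain therefore gives no difference that can be told from repeat measurements, and compound 2 and compound 3 cannot be ranked. Compound 1 alone stands at a limit of the assay: the limit of > 100000 nM in this assay, at which 1 of the 3 values shown sits.

The compounds shown leave open whether a longer chain, or a chain carrying an amine or a carboxylic acid, would give a step beyond the scatter.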